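Selenium-bridged diacyl series: methyl to benzyl on selenium

A few compounds are considered here, and "the series" means these few. Any claim that something is new, unique, unknown or untested is made for them only; others in the source may bear on it.

Three compounds of the series have been run in a functional assay on HepG2 cells (Homo sapiens) for cytotoxicity, read by MTT assay, with a stated time of 72 h; a higher number here means a weaker inhibitor of growth, a lower number a stronger inhibitor of growth. Compound 1 `C[Se]/C(=N\C(=O)c1cc2ccccc2s1)NC(=O)c1cc2ccccc2s1` gives 9590 nM. Compound 2 `C[Se]/C(=N\C(=O)c1cccs1)NC(=O)c1cccs1` gives 630 nM in this assay, and compound 3 `C[Se]/C(=N\C(=O)c1ccco1)NC(=O)c1ccco1` gives 760 nM. Among these three numbers compound 3 stands second highest; its nearest neighbour is compound 2, whose number lies within the scatter of it, so no order between compound 2 and compound 3 is claimed, while compound 1 lies furthest off, with a number beyond the scatter in the higher direction.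

Compound 4 `O=C(/N=C(/NC(=O)c1ccco1)[Se]Cc1ccccc1)c1ccco1` has not yet been measured. It differs from compound 3 in one place: phenyl in place of hydrogen on a saturated chain carbon bound to a selenium atom. For the measured compounds named here, no measured pair carries this same change, so there is no measured step to lean on, and the three numbers so far give no guide to its direction.

The expectation for compound 4 in this assay is 650 nM, with a range from 200 nM to 2200 nM. The step this estimate implies, a 1.2-fold lower number from compound 3 to compound 4 (0.07 log units; within the scatter), is expected to stay close to the scatter, with no direction assigned beyond it.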

Compound 4, concentration for 50% growth inhibition: 7650 nM
Compound 4: middle estimate off by 12-fold (1.07 log units), on the low side; measured number above the stated range.
By their numbers in this assay, from the lowest: compounds 2 and 3 (each within the scatter of the next); then compounds 4 and 1 (each within the scatter of the next).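

For the compounds shown here, the group on selenium is not a silent position in this assay: methyl to benzyl gives a 10-fold higher number from compound 3 to compound 4 (1.00 log units; beyond the scatter), a step beyond the scatter at a site that stays fixed as methyl in the earlier compounds. Going by these compounds alone, since this is the only difference within the pair, the weaker growth inhibition of compound 4 belongs to this single replacement, although only one pair supports it. Nothing available accounts for the size of this step.

From the compounds shown here alone, whether the step follows from the phenyl ring itself or from the larger group as a whole stays open; an ethyl group, a longer alkyl chain or a chain ending in a carboxylic acid in place of the methyl would help to separate these. Also open, going by these compounds, is whether methyl to benzyl acts alike on the core of compound 2.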